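Moving the amine around the pyridine ring of compound 2

This account rests on a few compounds, and the source may have more. Where it says the series, first, only, none or still open, it means among the compounds named here.

Three compounds share one core and differ in the pyridine ring attached to it and in the amine on the other side. Compound 1 `CCCN(Cc1ccccc1)c1cc(C)nc2c(-c3ncc(C(F)(F)F)cc3Cl)c(C)nn12` carries a chloro and trifluoromethyl pyridine with a propyl-benzyl amine and in an assay on isolated protein for binding affinity to corticotropin-releasing factor receptor 1 (Homo sapiens) (a lower number here means a stronger inhibitor, a higher number a weaker inhibitor), compound 1 gives 1.7 nM. Compound 2 `CCCN(CCC)c1cc(C)nc2c(-c3ncc(NC)cc3C)c(C)nn12` carries a dipropylamine and a methylamino pyridine, and in this assay compound 2 gives 40 nM, the highest of the three numbers. Compound 3 `CCCN(CCC)c1cc(C)nc2c(-c3ncc(N(CC)CC)cc3C)c(C)nn12` differs from compound 2 only in the amine on the pyridine; in this assay compound 3 gives 13 nM, so that a 3.1-fold lower number from compound 2 to compound 3 (0.49 log units; beyond the scatter).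

Compound 4 `CCCN(CCC)c1cc(C)nc2c(-c3ncc(C)cc3N)c(C)nn12` is the next step from compound 2: 3-amino-5-methylpyridin-2-yl in place of 3-methyl-5-(methylamino)pyridin-2-yl on an aromatic carbon. Going by the values given here, no measured pair shows this exchange; the only step touching the pyridine ring is the one from compound 2 to compound 3, and it was modest. The step from compound 2 to compound 4 is therefore expected to be modest as well, with no clear direction, a 1.5-fold higher number from compound 2 to compound 4 (0.18 log units; within the scatter). Compound 4 is estimated to give 60 nM in this assay, with a range from 15 nM to 250 nM.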

Compound 4, inhibition constant: 40 nM
Estimate against measurement, compound 4: 1.5-fold (0.18 log units) above, and the stated range covers the measured number.
By their numbers in this assay, from the lowest: compound 1; then compound 3; then compounds 2 and 4 (each within the scatter of the next).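

In this assay, putting 3-amino-5-methylpyridin-2-yl in place of 3-methyl-5-(methylamino)pyridin-2-yl gives no change at the digits printed from compound 2 to compound 4 (within the scatter), so a pyridine with its groups arranged differently and one heavy atom fewer stands level with the original on the shared core. Compound 3 showed only that the amine could be varied within the same arrangement; this pair shows that the arrangement itself can differ while the number stays within the scatter. Nothing available explains why the two pyridines match.

This pair differs both in where the amine sits and in the methyl on its nitrogen, so the two effects cannot be told apart and may even cancel. An amino group in place of the methylamino group of compound 2, or a diethylamino group in place of the amino group of compound 4, would help separate them.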